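The source may report more compounds than this note shows. Statements on the series, on what has been measured and on what is new or still open speak of the compounds shown alone.

Measured compounds in an ADME assay on MT4 cells (Homo sapiens) for cytotoxicity, read by MTT assay, with a stated time of 4 days; a lower number here means that less compound is tolerated, a higher number that more compound is tolerated:
compound 1 `O=C(COc1cccc2ccccc12)N/N=C/c1ccc(O)cc1` — 26.5 ug/mL
compound 2 `C/C(=N\NC(=O)COc1cccc2ccccc12)c1ccc([N+](=O)[O-])cc1` — 89.3 ug/mL
compound 3 `C/C(=N\NC(=O)COc1cccc2ccccc12)c1ccc(O)cc1O` — 59.9 ug/mL

Compound 1 gives the lowest of the three numbers; compound 3 and compound 2 both lie beyond the scatter above it. Compound 4 `O=C(COc1cccc2ccccc12)N/N=C/c1cccc(Br)c1` is not yet measured. Its change from compound 1: 3-bromophenyl in place of 4-hydroxyphenyl on a carbon with a double bond to nitrogen. Among the measured compounds shown here, one measured step touches the same position, the aryl group on the carbon with a double bond to nitrogen: a 1.5-fold lower number from compound 2 to compound 3 (0.17 log units; within the scatter), a swap of a 2,4-dihydroxyphenyl for a 4-nitrophenyl that left the number essentially unchanged. On that single precedent, no step beyond the scatter is expected for compound 4, though the ground is thin. The expected step is a 1.1-fold higher number from compound 1 to compound 4 (0.05 log units; within the scatter), and compound 4 is estimated at 30 ug/mL, with a range of 12 ug/mL to 75 ug/mL.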

Compound 4, half-maximal cytotoxic concentration: 87.4 ug/mL
Compound 4: the middle estimate sits 2.9-fold (0.46 log units) below what was measured, outside the stated range (above it).
By their numbers in this assay, from the lowest: compound 1; then compounds 3, 4 and 2 (each within the scatter of the next).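

In this assay, the aryl group on the carbon with a double bond to nitrogen proves able to move the number: a 3.3-fold higher number from compound 1 to compound 4 (0.52 log units; beyond the scatter), whereas a 1.5-fold lower number from compound 2 to compound 3 (0.17 log units; within the scatter) stayed within the scatter. The change from 4-hydroxyphenyl to 3-bromophenyl removes the hydrogen-bond donor and acceptor counted on the leaving group and brings in bromine, all in one step. No measurement on hand accounts for this step.

From the compounds shown here alone, whether the step follows the loss of the hydroxyl, the arrival of the bromine or the changed placement on the ring stays open. Going by these compounds, how an amine or a carboxylic acid on this aryl ring would read is also open.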